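The source may hold more compounds than are shown below. What is called first, only, known or untested is meant among the compounds shown, and "the series" means these compounds.

Measured so far:
compound 1 `Cc1ccc(C(C)C)c(OCc2nnc(SCC(=O)Nc3ccc(S(N)(=O)=O)cc3)n2Cc2ccccc2)c1` — 13 ug/mL
compound 2 `Cc1ccc(C(C)C)c(OCc2nnc(SCC(=O)Nc3ccc([N+](=O)[O-])cc3)n2Cc2ccccc2)c1` — 11.2 ug/mL

In a toxicity assay on MT4 cells (Homo sapiens) for cytotoxicity, read by MTT assay, with a stated time of 5 days (on this read-out higher numbers stand for lower toxicity in this test and lower numbers for higher toxicity in this test), compound 1 gives 13 ug/mL and compound 2 gives 11.2 ug/mL. Among the measured compounds shown here, compound 2 stands beside compound 1 within the usual scatter; a 1.2-fold lower number from compound 1 to compound 2 (0.06 log units; within the scatter) is the only step on record, and it swaps the group on the anilide ring while the ether side of the shared core is left untouched.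

Compound 3 `O=C(CSc1nnc(COc2ccc3ccccc3c2)n1Cc1ccccc1)Nc1ccc([N+](=O)[O-])cc1` is the next step: naphthalen-2-yl in place of 2-isopropyl-5-methylphenyl on an oxygen on a saturated carbon. For the measured compounds named here, no measured pair changes this part of the molecule, so the one recorded step gives no direct guidance on the size or direction of the effect in this assay. With nothing to argue for a move beyond the scatter, the working assumption is a number near compound 2 with a wide band of uncertainty.

Compound 3 is therefore expected near 11 ug/mL, with a range of 4 ug/mL to 30 ug/mL. The estimated step this implies is a 1.0-fold lower number from compound 2 to compound 3 (0.01 log units; within the scatter), to be confirmed by measurement.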

Compound 3, half-maximal cytotoxic concentration: >= 116 ug/mL
Compound 3 was reported as a limit; the forecaster's own chance of this, stated with the estimate: 10%; middle value at least 10-fold (1.02 log units) away from the limit.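

On the ether side of the shared core, naphthalen-2-yl in place of 2-isopropyl-5-methylphenyl gives an at least 10-fold higher number from compound 2 to compound 3 (1.01 log units; beyond the scatter) in this assay, so this position, left untouched by the earlier pair, moves the read-out far more than the swap on the anilide ring, which gave a 1.2-fold lower number from compound 1 to compound 2 (0.06 log units; within the scatter). Both groups count 10 heavy atoms, all carbon, with no hydrogen-bond donors or acceptors and no net charge, so the step comes with no change in those counts; what differs is one six-membered aromatic ring bearing isopropyl and methyl against 2 such rings of carbon only. For compound 3 the reading >= 116 ug/mL is a limit of the assay and not a number: the limit of >= 116 ug/mL in this assay, at which 1 of the 3 values shown sits.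

The compounds shown do not separate the gain of the second aromatic ring from the loss of the isopropyl and methyl groups, and naphthalen-2-yl appears here only with the nitro group on the anilide ring, so its effect alongside sulfamoyl remains open. Also open, from the compounds shown here alone, is how this position responds to an unsubstituted phenyl, or to a phenyl carrying a carboxylic acid or an amine.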